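A few compounds are considered here, and "the series" means these few. Any claim that something is new, unique, unknown or untested is made for them only; others in the source may bear on it.

Working notes on the series, values from a physicochemical assay for lipophilicity (on this read-out lower numbers stand for lower lipophilicity and higher numbers for higher lipophilicity), as measured

- compound 1 `COc1c(OC)c(OC(=O)C(C)C)c2ccccc2c1OC(=O)C(C)C` gives 4.61 as measured
- compound 2 `COc1c(OC)c(OC(C)=O)c2cc(Br)ccc2c1OC(C)=O` gives 3.39 as measured

Compound 1 stands highest of the two numbers in hand, and compound 2 sits lower by a gap beyond the usual scatter. Among the compounds with values here, no step between measured compounds that differ in one place is available, so that gap cannot be read as the result of any single change.

The next compound to read is compound 3 `COc1c(OC)c(OC(=O)C(C)C)c2cc(Cl)ccc2c1OC(=O)C(C)C`, which departs from compound 1 in one place: chloro in place of hydrogen on an aromatic carbon, with chloro in place of hydrogen on an aromatic carbon. Within the data shown here, with no measured step to lean on, the expectation rests on this structural change alone. A rise in this assay is expected, of a size beyond the scatter but smaller than the gap between compound 1 and compound 2. The estimated move is a number 0.59 log units higher from compound 1 to compound 3 (beyond the scatter) in the upward direction. For compound 3 the expected value is 5.2 within an estimated range from 4.8 to 5.6 at its ends.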

Compound 3, partition coefficient: 5.4
The estimate for compound 3 lay 0.20 log units below the measured number, and the stated range covers the measured number.
By their numbers in this assay, from the lowest: compound 2; then compound 1; then compound 3.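

In this assay, within the data shown here, chloro in place of hydrogen on an aromatic carbon, meta to a fused ring and para to a fused ring, gives a number 0.79 log units higher from compound 1 to compound 3 (beyond the scatter) as the first step that can be read at a single place. The rest of the structure is unchanged, so this rise belongs to that one replacement, which the earlier gap between two compounds differing in more than one place could not show. Nothing in hand accounts for the direction or size of this step at this position.

A single replacement at a single position is shown, so it remains open whether an amine or a carboxylic acid on the same aromatic carbon would move the number in the same direction, and whether chloro on another aromatic carbon of the shared core would match this step. Also open, from the compounds shown here alone, is whether the step would keep its size with a longer chain on the carbonyl groups of the core of compound 1.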